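The compounds below may be only part of what the source reports. "The series", "measured", "known", "first", "only" and "open" are said of these compounds alone.

Measured so far:
compound 1 `O=C(Nc1cccc(-n2cc(-c3ccncc3)c(-c3cc(O)cc(Cl)c3)n2)c1)Nc1ccc(Cl)c(C(F)(F)F)c1`: -52%
compound 2 `O=C(Nc1cccc(-n2cc(-c3ccncc3)c(-c3cc(O)cc(Cl)c3)n2)c1)Nc1ccc(Cl)c(Cl)c1`: -48%
compound 3 `COc1cc(Cl)cc(-c2nn(-c3cccc(NC(=O)Nc4ccc(Cl)c(Cl)c4)c3)cc2-c2ccncc2)c1`: -8%

These three compounds share one core and were read in a functional assay on NCI-H460 cells (Homo sapiens) for inhibition, read by sulforhodamine B assay, with a stated time of 48 h, tested at 100 uM; on this read-out lower numbers stand for a stronger effect and higher numbers for a weaker effect at the one concentration tested. Compound 1 gives -52% and compound 2 gives -48%, and the step of a number 4 percentage points higher from compound 1 to compound 2 (within the scatter) shows that swapping the groups on the outer ring changed little. The step of a number 40 percentage points higher from compound 2 to compound 3 (beyond the scatter) is different: capping the hydroxyl on the core as a methyl ether moved the number a long way towards the weaker end. Compound 3 therefore stands highest of the three, beyond the scatter from compound 2 and from compound 1.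

Compound 4 `COc1cc(Cl)cc(-c2nn(-c3cccc(NC(=O)c4cccc(C(F)(F)F)c4)c3)cc2-c2ccncc2)c1` keeps the methyl ether of compound 3 and changes the other end: 3-(trifluoromethyl)phenyl in place of (3,4-dichlorophenyl)amino on a carbonyl carbon. The urea link becomes an amide, with the trifluoromethyl-bearing ring now joined straight to the carbonyl. Going by the values given here, no measured step covers the loss of that nitrogen. Among the compounds with values here, the only related step, from compound 1 to compound 2, changed the groups on this same outer ring and stayed within the scatter. Within the data shown here, with that as the sole guide, and the methyl ether of compound 3 retained, compound 4 is expected to stay close to compound 3, with a step of no change at the digits printed from compound 3 to compound 4 (within the scatter) that is not expected to exceed the scatter, though the untested change to the link leaves the range wide. Compound 4 is estimated at -8%, between -45% and 20%.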

Compound 4, a percentage reported as activity, at one concentration (the size of the read-out at that concentration, not a potency): 30%
Compound 4: middle estimate off by 38 percentage points, on the low side, and the stated range ends below it.
By their numbers in this assay, from the lowest: compounds 1 and 2 (each within the scatter of the next); then compound 3; then compound 4.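

The swap of (3,4-dichlorophenyl)amino for 3-(trifluoromethyl)phenyl on the carbonyl carbon, read in this assay, gives a number 38 percentage points higher from compound 3 to compound 4 (beyond the scatter), so this end of the molecule is not as tolerant of change as the earlier outer-ring swap suggested. That earlier swap, a number 4 percentage points higher from compound 1 to compound 2 (within the scatter), kept the urea link and altered only the ring, whereas this one also removes the amino nitrogen, with its hydrogen-bond donor, from the carbonyl carbon. Nothing measured here explains the shift.

The ring and the link change together in this single step, so their shares cannot be separated. As far as these compounds go, a (3-(trifluoromethyl)phenyl)amino group on the same carbonyl carbon would keep the nitrogen and change only the ring, and the amide's reading with the free hydroxyl in place of the methyl ether also remains open.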